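One Side Group Exchanged, Compound 3 to Compound 4

The source may hold more compounds than are shown below. What is called first, only, known or untested is meant among the compounds shown, and "the series" means these compounds.

In an ADME assay on HeLa cells (Homo sapiens) for cytotoxicity, read by MTT assay (a higher number here means a weaker inhibitor, a lower number a stronger inhibitor), compound 3 `COc1ccc(C[C@H]2COC(=O)[C@@H]2Cc2ccc(OCC(=O)N3CCCCC3)c(OC)c2)cc1OC` gives 293000 nM. Compound 2 `COc1ccc(C[C@H]2COC(=O)[C@@H]2Cc2ccc(OCC(=O)Nc3ccc(C)cc3)c(OC)c2)cc1OC` gives 228000 nM, within the scatter of compound 3, so the two count as level. Only against compound 1 `COC(=O)[C@@H]1CCCN1C(=O)CCC(=O)Oc1ccc(C[C@H]2C(=O)OC[C@@H]2Cc2ccc(OC)c(OC)c2)cc1OC`, at 145000 nM, does compound 3 stand beyond the scatter, on the higher side.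

Compound 4 `COc1ccc(C[C@H]2COC(=O)[C@@H]2Cc2ccc(OC(=O)CCC(=O)N3CCCC3)c(OC)c2)cc1OC` has not yet been measured. Its change from compound 3 is a group of 11 heavy atoms (8 carbon, 1 nitrogen, 2 oxygen; one five-membered non-aromatic ring with 1 hetero atom) in place of a group of 9 heavy atoms (7 carbon, 1 nitrogen, 1 oxygen; one six-membered non-aromatic ring with 1 hetero atom), on an oxygen on an aromatic ring. The group that leaves is ((piperidin-1-yl)carbonyl)methyl.

Among the compounds with values here, no measured step covers this exact exchange. The nearest evidence is a 1.3-fold higher number from compound 2 to compound 3 (0.11 log units; within the scatter), where piperidin-1-yl replaced (4-methylphenyl)amino on a carbonyl carbon and the number stayed within the scatter. That single step suggests that these compounds tolerate a change in this part of the molecule without much movement. Compound 1 also carries a five-membered non-aromatic ring with 1 hetero atom, and its value of 145000 nM pulls the expectation slightly downward.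

The expected change is therefore small, a 1.3-fold lower number from compound 3 to compound 4 (0.12 log units; within the scatter), with no step beyond the scatter expected. For compound 4 the estimated value is 220000 nM, with an expected range from 120000 nM to 400000 nM.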

Compound 4, half-maximal inhibitory concentration: 201000 nM
The estimate for compound 4 lay 1.1-fold (0.04 log units) above the measured number; low and high end bracket the measured number.
By their numbers in this assay, from the lowest: compounds 1, 4, 2 and 3 (each within the scatter of the next, the first and the last beyond it).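

In this assay, exchanging the whole ((piperidin-1-yl)carbonyl)methyl group on an oxygen on an aromatic ring gives a 1.5-fold lower number from compound 3 to compound 4 (0.16 log units; within the scatter) and so stays level; the earlier step had changed only the group on a carbonyl carbon, whereas this one shows that a wider exchange at this oxygen also stays within the scatter. The result is the same when the group leaving carries a six-membered aromatic ring of carbon only, with a 1.1-fold lower number from compound 2 to compound 4 (0.05 log units; within the scatter) as the step, and a five-membered non-aromatic ring enters in its place. The step with hydrogen in place of methoxycarbonyl on a saturated ring carbon is a 1.4-fold higher number from compound 1 to compound 4 (0.14 log units; within the scatter) and is also within the scatter, so compound 4 is level with each of the other three compounds, even though compound 1 and compound 3 stand beyond the scatter of each other.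

On these data alone, compound 4 differs from compound 3 in both its ring and the chain leading to it, so the effect of each change alone remains unknown. As far as these compounds go, it also remains open whether an amine or a carboxylic acid at the end of the group on this oxygen would move the number beyond the scatter. Nothing available explains why these exchanges leave the number so nearly level.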